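The source may hold more compounds than are shown below. What is called first, only, known or untested is meant among the compounds shown, and "the series" means these compounds.

Measured compounds:
- compound 1 `COc1ccccc1/C=c1/[nH]c(=O)/c(=C\c2ccccc2OC)n(C)c1=O` — in a functional assay on HL-60 cells (Homo sapiens) for cytotoxicity, read by CCK-8 assay, with a stated time of 72 h (on this read-out lower numbers stand for stronger inhibition and higher numbers for weaker inhibition), compound 1 gives 16200 nM
- compound 2 `C=CCn1c(=O)/c(=C\c2cc(Br)ccc2F)[nH]c(=O)/c1=C\c1ccccc1OC` — in this assay compound 2 gives 17400 nM
- compound 3 `COc1ccccc1/C=c1\c(=O)[nH]/c(=C/c2cccc(Cl)c2Cl)c(=O)n1C` — in this assay compound 3 gives 200 nM

Compound 2 stands at the highest number of the three. Its gap to compound 1 lies within the scatter, so the two cannot be told apart, while compound 3 sits far lower. Going by the values given here, the one step that was measured in one place, an 81-fold lower number from compound 1 to compound 3 (1.91 log units; beyond the scatter), shows how strongly an exchange of the aryl group on this position can move the read-out.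

Compound 4 `C=CCn1c(=O)/c(=C\c2cccc(C)c2)[nH]c(=O)/c1=C\c1ccccc1OC` is not yet measured. It differs from compound 2 by 3-methylphenyl in place of 5-bromo-2-fluorophenyl on a double-bonded chain carbon bound to an aromatic carbon. Among the compounds with values here, no measured pair shows what happens when a halogenated phenyl is replaced by a methyl-bearing phenyl at this position, so the step from compound 1 to compound 3 bears on the place but not on the groups exchanged. Within the data shown here, compound 3, the only compound with a low number, carries two chlorines on its aryl group; compound 4 carries none. On that basis a step near or somewhat above the value of compound 2 in this assay is expected, not beyond the scatter with confidence. The expected step is a 1.1-fold higher number from compound 2 to compound 4 (0.06 log units; within the scatter). For compound 4 the estimate in this assay is 20000 nM, ranging from 6000 nM to 70000 nM.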

Compound 4, half-maximal inhibitory concentration: 16700 nM
For compound 4 the middle estimate is 1.2-fold (0.08 log units) above the measured one, within the range that was stated.
By their numbers in this assay, from the lowest: compound 3; then compounds 1, 4 and 2 (each within the scatter of the next).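

In this assay, exchanging 5-bromo-2-fluorophenyl for 3-methylphenyl on a double-bonded chain carbon bound to an aromatic carbon gives a 1.0-fold lower number from compound 2 to compound 4 (0.02 log units; within the scatter), so on this core a phenyl with bromine and fluorine and a phenyl with only a methyl group cannot be told apart. The earlier compounds shown here showed only that this place can respond strongly, through an 81-fold lower number from compound 1 to compound 3 (1.91 log units; beyond the scatter); the new pair shows that an aryl exchange here can also leave the number unchanged, and that a halogenated phenyl does not by itself give a low number on the core shared by compound 2 and compound 4. Nothing further is available to explain this flat result, which stands only as an observation.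

The compounds shown leave open whether 2,3-dichlorophenyl at this place would give a low number on the core of compound 2 as well, or whether the large step is tied to the core of compound 1 and compound 3. They also leave open how a phenyl carrying a carboxylic acid or an amine would read here.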